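The source may hold more compounds than are shown below. What is called first, only, known or untested is meant among the compounds shown, and "the series" means these compounds.

Compound 3 `COc1cc(/C=C/C(=O)c2cccc(-n3cc(-c4ccc(F)cc4)nn3)c2)ccc1O` gives 6450 nM in a functional assay on RAW264.7 cells (Mus musculus) for inhibition, with a stated time of 4 days; a lower number here means a stronger inhibitor, a higher number a weaker inhibitor. Compound 2 `C=C(C)c1cn(-c2cccc(C(=O)/C=C/c3ccc(O)c(OC)c3)c2)nn1` gives 9790 nM in this assay, and compound 1 `COc1cc(/C=C/C(=O)c2cccc(-n3cc(C(C)(C)O)nn3)c2)ccc1O` gives 19800 nM in this assay. Compound 3 thus has the lowest number of the three, with a 3.1-fold lower number from compound 1 to compound 3 (0.49 log units; beyond the scatter) and a 1.5-fold lower number from compound 2 to compound 3 (0.18 log units; within the scatter); the latter lies within the scatter, so compound 2 and compound 3 cannot be told apart. Compound 4 `COc1ccc(-c2cn(-c3cccc(C(=O)/C=C/c4ccc(O)c(OC)c4)c3)nn2)cc1` differs from compound 3 by methoxy in place of fluoro on an aromatic carbon. Among the measured compounds shown here, none of the measured steps touches this position: all three, including a 2.0-fold lower number from compound 1 to compound 2 (0.31 log units; beyond the scatter), exchange the entire group on an aromatic carbon of the shared core. For the measured compounds named here, with no direct precedent, the step of a 1.1-fold lower number from compound 3 to compound 4 (0.03 log units; within the scatter) is expected to stay within the scatter. Compound 4 is therefore estimated at 6000 nM, ranging from 2500 nM to 15000 nM.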

Compound 4, half-maximal inhibitory concentration: 7900 nM
Compound 4: the middle estimate sits 1.3-fold (0.12 log units) below what was measured, within the range that was stated.
By their numbers in this assay, from the lowest: compounds 3, 4 and 2 (each within the scatter of the next); then compound 1.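

Exchanging fluoro for methoxy leaves the number in this assay within the scatter, with a 1.2-fold higher number from compound 3 to compound 4 (0.09 log units; within the scatter) as the step, so compound 3 and compound 4 cannot be told apart. The 4-methoxyphenyl group also cannot be separated from 1-methylethenyl, given a 1.2-fold lower number from compound 2 to compound 4 (0.09 log units; within the scatter) as the step, whereas a 2.5-fold lower number from compound 1 to compound 4 (0.40 log units; beyond the scatter) lies beyond the scatter and sets compound 1 apart once more. Nothing available here explains these results. As far as these compounds go, what an amine or a carboxylic acid would do in this place, para to a large group, stays open.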